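Methyl on the anilino ring of a weakly cytotoxic series

A few compounds are considered here, and "the series" means these few. Any claim that something is new, unique, unknown or untested is made for them only; others in the source may bear on it.

Among the measured compounds shown here, compound 1 `Fc1cccc(-c2nc(Nc3ccccc3)c3cc(F)ccc3n2)c1` is the only member of the set with a numeric value in a functional assay on U-937 cells (Homo sapiens) for cytotoxicity, read by MTT assay, with a stated time of 48 h; a higher number here means a weaker inhibitor, a lower number a stronger inhibitor: compound 1 gives 45500 nM. Compound 2 `Fc1cccc(-c2nc(Nc3ccccc3Br)c3cc(F)ccc3n2)c1` carries bromo in place of hydrogen on an aromatic carbon; in this assay compound 2 reaches only the assay limit of > 50000 nM. Compound 3 `Nc1ccc(Nc2nc(-c3cccc(F)c3)nc3ccc(F)cc23)cc1` carries amino in place of hydrogen on an aromatic carbon; in this assay compound 3 likewise stops at the limit of > 50000 nM. Both steps from the parent, an at least 1.0-fold higher number from compound 1 to compound 2 (0.04 log units; that floor lies within the scatter) and an at least 1.0-fold higher number from compound 1 to compound 3 (0.04 log units; that floor lies within the scatter), are therefore floors that do not rise beyond the scatter, because of the limit of > 50000 nM in this assay, at which 2 of the 3 values shown sit, at which two of the three values sit. The remaining pair, a step that the two limits leave unreadable from compound 2 to compound 3, cannot be read.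

Compound 4 `Cc1ccccc1Nc1nc(-c2cccc(F)c2)nc2ccc(F)cc12` differs from compound 1 by methyl in place of hydrogen on an aromatic carbon. For the measured compounds named here, the steps that bear on it are the two substitutions of hydrogen on an aromatic carbon, an at least 1.0-fold higher number from compound 1 to compound 2 (0.04 log units; that floor lies within the scatter) and an at least 1.0-fold higher number from compound 1 to compound 3 (0.04 log units; that floor lies within the scatter), both small at their floors and both ending at the limit. No step beyond the scatter is therefore expected in this assay, and a limit is about as likely as a number. Compound 4 is expected at 50000 nM, between 25000 nM and 100000 nM. The expected step is a 1.1-fold higher number from compound 1 to compound 4 (0.04 log units; within the scatter), within the scatter.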

Compound 4, half-maximal inhibitory concentration: > 50000 nM
Compound 4 gave a limit, no number; the forecaster's own chance of this, stated with the estimate: 50%; the middle value sits exactly at the limit.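

In this assay compound 4 gives > 50000 nM, which is a limit and not a number. Methyl, ortho to a large group, therefore joins bromo and amino as a third group on the anilino ring that gives no numeric value, and the step, an at least 1.0-fold higher number from compound 1 to compound 4 (0.04 log units; that floor lies within the scatter), is only a floor: it shows neither a real loss relative to the parent nor its absence. The steps among compound 2, compound 3 and compound 4 cannot be read, because all three end at one ceiling, so methyl and bromo cannot be ranked against each other at this position: the limit of > 50000 nM in this assay, at which 3 of the 4 values shown sit.

Still open, going by these compounds, is whether any group on the anilino ring can move the read-out to a clearly lower number than compound 1 gives, 45500 nM, for example a carboxylic acid, a dimethylamino group or a longer chain such as propyl in place of the methyl. With no substituted compound giving a number, the compounds shown also leave the size of the methyl step unknown, and no order of groups on this ring can be drawn from them.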